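A few compounds are considered here, and "the series" means these few. Any claim that something is new, unique, unknown or untested is made for them only; others in the source may bear on it.

Measured in a functional assay on NCI/ADR-RES cells (Homo sapiens) for antiproliferative activity, read by sulforhodamine B assay, with a stated time of 48 h; a lower number here means a stronger inhibitor of growth, a higher number a weaker inhibitor of growth:
- Compound 1 `CCCCCCCC/C=C\CCCCCCCC(=O)N1CCCC1`: 0.2 ug/mL
- Compound 2 `CCCCCCCCCCCCCCCC(=O)N1CCOCC1`: 6.2 ug/mL

Compound 1 has the lower of these two numbers, and the gap to compound 2 lies beyond the scatter. Compound 3 `CCCCCCCC/C=C\CCCCCCCC(=O)N1CCOCC1` is unmeasured. It keeps the core of compound 1 but carries morpholin-4-yl in place of pyrrolidin-1-yl on a carbonyl carbon. Among the compounds with values here, no measured pair shows this change alone. Compound 2, which also carries morpholin-4-yl on a different chain, gives 6.2 ug/mL, so a higher number is expected. The expected rise, beyond the scatter, is a 7.5-fold higher number from compound 1 to compound 3 (0.88 log units; beyond the scatter). In this assay the estimate for compound 3 is 1.5 ug/mL, expected between 0.4 ug/mL and 6 ug/mL.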

Compound 3, concentration for 50% growth inhibition: 3.3 ug/mL
Estimate against measurement, compound 3: 2.2-fold (0.34 log units) below, within the range that was stated.
By their numbers in this assay, from the lowest: compound 1; then compounds 3 and 2 (each within the scatter of the next).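

In this assay, the chain stays fixed and only the group on the carbonyl carbon changes, so morpholin-4-yl in place of pyrrolidin-1-yl accounts for a 17-fold higher number from compound 1 to compound 3 (1.22 log units; beyond the scatter) in this pair. Growth inhibition therefore depends strongly on which ring sits at this position, at least on this chain. Nothing measured here explains the size of this step.

From the compounds shown here alone, whether piperidin-1-yl or an open-chain diethylamino group on the same carbonyl carbon would sit closer to compound 1 or compound 3 remains open. Also open, going by these compounds, is whether pyrrolidin-1-yl would give a similar gain on the chain of compound 2.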